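Aryl swap on a shared core: estimating compound 3

A few compounds are considered here, and "the series" means these few. Any claim that something is new, unique, unknown or untested is made for them only; others in the source may bear on it.

Measured compounds:
compound 1 `COc1cc(C(=O)c2sc(-c3ccc([N+](=O)[O-])cc3)cc2N)cc(OC)c1OC` gives 64 nM in a functional assay on FM3A cells (Mus musculus) for antiproliferative activity; a lower number here means a stronger inhibitor, a higher number a weaker inhibitor
compound 2 `COc1cc(C(=O)c2sc(-c3ccccc3Cl)cc2N)cc(OC)c1OC` gives 34 nM

Compound 1 holds the higher of the two numbers, and its step to compound 2 a 1.9-fold lower number from compound 1 to compound 2 (0.27 log units; within the scatter) stays inside the scatter. Compound 3 `COc1cc(C(=O)c2sc(-c3ccc(F)cc3)cc2N)cc(OC)c1OC` differs from compound 1 by fluoro in place of nitro on an aromatic carbon. For the measured compounds named here, only the step from compound 1 to compound 2 bears on this, and it was small. For compound 3 the expected step is therefore small, a 1.4-fold lower number from compound 1 to compound 3 (0.15 log units; within the scatter), with no direction beyond the scatter. The estimate for compound 3 is 45 nM, ranging from 15 nM to 140 nM.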

Compound 3, half-maximal inhibitory concentration: 16 nM
Estimate against measurement, compound 3: 2.8-fold (0.45 log units) above, and the stated range covers the measured number.
By their numbers in this assay, from the lowest: compound 3; then compounds 2 and 1 (each within the scatter of the next).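

In this assay the aryl group on the shared core now gives steps beyond the scatter: a 4.0-fold lower number from compound 1 to compound 3 (0.60 log units; beyond the scatter), and a 2.1-fold lower number from compound 2 to compound 3 (0.33 log units; beyond the scatter). The position therefore responds to this change, which the step between compound 1 and compound 2, within the scatter, did not show. Nothing available here accounts for the difference. The compounds shown leave open how an amine or a carboxylic acid would read in place of fluoro on the same six-membered aromatic ring. They also leave open whether chloro at that same place would match fluoro.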